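A few compounds are considered here, and "the series" means these few. Any claim that something is new, unique, unknown or untested is made for them only; others in the source may bear on it.

Three compounds share a core and differ only in a side chain hanging from it. Compound 1 `COc1ccc(-c2cc(/C=C/C(=O)c3cc(OC)c(OC)c(OC)c3)nc3cc(-c4ccccc4)nn23)cc1OC` and compound 3 `COc1ccc(-c2cc(/C=C/C(=O)c3ccc(C)cc3)nc3cc(-c4ccccc4)nn23)cc1OC` join that chain one way; compound 2 `COc1ccc(-c2cc(C(=O)/C=C/c3ccc(C)cc3)nc3cc(-c4ccccc4)nn23)cc1OC` has the same atoms joined differently, as described by (2-(4-methylphenyl)ethenyl)carbonyl in place of 2-((4-methylphenyl)carbonyl)ethenyl on an aromatic carbon. In an ADME assay on HEK293 cells (Homo sapiens) for antiproliferative activity, read by MTT assay, with a stated time of 24 h (a higher number here means a weaker inhibitor, a lower number a stronger inhibitor), compound 1 gives 35000 nM, compound 2 gives 57400 nM and compound 3 gives 62600 nM. The rearrangement gave a 1.1-fold higher number from compound 2 to compound 3 (0.04 log units; within the scatter), a step within the scatter. Swapping the aryl group at the end of the chain, (3,4,5-trimethoxyphenyl in place of 4-methylphenyl on a carbonyl carbon), gave a 1.8-fold lower number from compound 3 to compound 1 (0.25 log units; within the scatter), also within the scatter.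

Compound 4 `COc1ccc(-c2cc(C(=O)/C=C/c3cc(OC)c(OC)c(OC)c3)nc3cc(-c4ccccc4)nn23)cc1OC` applies the same kind of swap to compound 2, (3,4,5-trimethoxyphenyl in place of 4-methylphenyl on a double-bonded chain carbon bound to a double-bonded chain carbon). The place differs: in compound 4 the new group sits on a double-bonded chain carbon bound to a double-bonded chain carbon, whereas in compound 1 it sits on a carbonyl carbon whose other neighbour is a double-bonded chain carbon. The step of a 1.7-fold lower number from compound 2 to compound 4 (0.24 log units; within the scatter) is expected to be small. That expectation rests on compound 1 and compound 3, where a 1.8-fold lower number from compound 3 to compound 1 (0.25 log units; within the scatter) stayed within the scatter. Compound 4 is therefore estimated at 33000 nM, probably between 15000 nM and 70000 nM.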

Compound 4, half-maximal inhibitory concentration: 46800 nM
For compound 4 the middle estimate is 1.4-fold (0.15 log units) below the measured one; the measured number falls inside the stated range.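

In this assay, putting 3,4,5-trimethoxyphenyl in place of 4-methylphenyl gave a 1.2-fold lower number from compound 2 to compound 4 (0.09 log units; within the scatter), so with the side chain joined this second way the change again stays within the ordinary spread of repeat measurements. Set beside the earlier case, the two steps cannot be told apart: the same change on two cores in this assay, a 1.8-fold lower number (0.25 log units; within the scatter) from compound 3 to compound 1 and a 1.2-fold lower number (0.09 log units; within the scatter) from compound 2 to compound 4, 1.5-fold (0.16 log units) apart, within the scatter of two such steps. Among these compounds, this shows that the change carried over between these two cores without a detectable difference, but because each step is itself within the scatter, the agreement shows only that the change is small in both, not that it has a real effect of a consistent size or direction, and two pairs cannot speak for other cores.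

The compounds shown leave open whether any other replacement for this group, such as an amine or a carboxylic acid in place of the 3,4,5-trimethoxyphenyl, would move the number beyond the scatter. They also leave open whether the same agreement would hold for a longer chain.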